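This account rests on a few compounds, and the source may have more. Where it says the series, first, only, none or still open, it means among the compounds named here.

Measured compounds:
Compound 1, `C/C(=N\O)c1ccc2[nH]c(-c3ccc(C(F)(F)F)cc3)nc2c1`, in an ADME assay on Vero cells (Chlorocebus sabaeus) for cytotoxicity, read by MTT assay, with a stated time of 96 h; a higher number here means that more compound is tolerated, a lower number that less compound is tolerated: "not determined" (no result reported).
Compound 2, `C/C(=N\NC(N)=O)c1ccc2[nH]c(-c3ccccc3)nc2c1`, in this assay: > 100000 nM, which is a limit of the assay and not a number.

Compound 2 therefore stands only at a limit in this assay; the other entry holds no number, so its place is set by the limit of > 100000 nM in this assay, at which 1 of the 2 values shown sits, alone. Compound 3, `C/C(=N\NC(N)=O)c1ccc2[nH]c(-c3ccc(C(F)(F)F)cc3)nc2c1`, is not yet measured in this assay. It differs from compound 2 by trifluoromethyl in place of hydrogen on an aromatic carbon. Among the compounds with values here, no measured step covers this change. The step of a number no higher from compound 2 to compound 3 (the limit leaves the size open) is expected to be none beyond the scatter. Compound 3 is expected at 100000 nM in this assay, with a range from 30000 nM to 300000 nM, most likely reported again only as a limit.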

Compound 3, half-maximal cytotoxic concentration: > 100000 nM
Compound 3: a limit, no number (the forecaster's own chance of this, stated with the estimate: 70%); the middle value lies on the limit itself.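

Compound 2 gives > 100000 nM in this assay, a limit and not a number. Compound 3 gives > 100000 nM, also a limit, so no step can be read between compound 2 and compound 3. Where the half-maximal cytotoxic concentration of either compound lies, and whether trifluoromethyl in place of hydrogen shifts it, stays open.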